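Notes on compound 2 and the pending compound 3

The source may hold more compounds than are shown below. What is called first, only, known or untested is meant among the compounds shown, and "the series" means these compounds.

Measured so far:
compound 1, `CC(=O)Oc1ccc(C(=O)Nc2cc3ccc(OCC4CCN(C)C4)c(C)c3oc2=O)cc1CC=C(C)C`, 880 nM
compound 2, `CCCNCCCOc1ccc2cc(NC(=O)c3ccc(O)c(CC=C(C)C)c3)c(=O)oc2c1C`, 990 nM

In a functional assay on SK-BR-3 cells (Homo sapiens) for antiproliferative activity (on this read-out higher numbers stand for weaker inhibition and lower numbers for stronger inhibition), compound 2 and compound 1 lie within the scatter of each other, so compound 2 stands apart from nothing in the set. Compound 3, `CC(C)=CCc1cc(C(=O)Nc2cc3ccc(OCCCNc4ccccc4)c(C)c3oc2=O)ccc1O`, is not yet measured. It differs from compound 2 in one place: phenyl in place of propyl on an amine nitrogen. For the measured compounds named here, no step between measured compounds covers this change, and the two values give no direction for it. The expectation is therefore a step of a 1.0-fold higher number from compound 2 to compound 3 (0.00 log units; within the scatter) that stays within the scatter of this assay. Compound 3 is estimated at 1000 nM, with a range of 400 nM to 2500 nM.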

Compound 3, half-maximal inhibitory concentration: > 50000 nM
Compound 3: only a limit was reported; the forecaster's own chance of this, stated with the estimate: 3%; at least 50-fold (1.69 log units) between middle value and limit.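

On an amine nitrogen, phenyl in place of propyl gives an at least 50-fold higher number from compound 2 to compound 3 (1.70 log units; beyond the scatter) in this assay, so the group on this nitrogen can decide whether any activity is seen at all. The earlier compounds shown here alone showed no such sensitivity at this position. For compound 3, the value of > 50000 nM is a limit of the assay and not a number: the limit of > 50000 nM in this assay, at which 1 of the 3 values shown sits.

The compounds shown leave open whether a cyclohexyl or a benzyl group on this nitrogen behaves like propyl or like phenyl. They also leave open how a longer chain in place of propyl would read.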